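Working notes on the shared core: step to compound 4

This account rests on a few compounds, and the source may have more. Where it says the series, first, only, none or still open, it means among the compounds named here.

Of the compounds shown here, three on the shared core have been measured in a functional assay on HepG2 cells (Homo sapiens) for antiproliferative activity, read by MTT assay, with a stated time of 48 h; on this read-out lower numbers stand for stronger inhibition and higher numbers for weaker inhibition. Compound 1 `COc1ccc(-c2ccc3c(c2)C(=O)C(=O)N3Cc2ccc(Br)cc2)cc1` gives 700 nM, compound 2 `COc1ccc(-c2ccc3c(c2)C(=O)C(=O)N3Cc2ccc(C)cc2)cc1` gives 330 nM, and compound 3 `COc1ccc(CN2C(=O)C(=O)c3cc(-c4cc(OC)cc(OC)c4)ccc32)cc1` gives 1200 nM. Compound 3 thus carries the highest of the three numbers; its gap to compound 1 lies within the scatter, while its gap to compound 2 lies beyond it. Among the measured compounds shown here, the only single-place step measured so far, a 2.1-fold lower number from compound 1 to compound 2 (0.33 log units; beyond the scatter), concerns a group elsewhere on the core and is modest in size.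

Compound 4 `COc1ccc(CN2C(=O)C(=O)c3cc(-c4ccc(C#N)cc4)ccc32)cc1` differs from compound 3 in one place: 4-cyanophenyl in place of 3,5-dimethoxyphenyl on an aromatic carbon. For the measured compounds named here, no measured step touches the group at this position, as compounds 1 and 2 each differ from compound 3 in two places at once. Going by the values given here, with no step to lean on, no change beyond the scatter is expected in this assay in either direction, and the range is kept wide. For compound 4 the expected value in this assay is estimated at 900 nM, between 300 nM and 3000 nM. The expected step is a 1.3-fold lower number from compound 3 to compound 4 (0.12 log units; within the scatter).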

Compound 4, half-maximal inhibitory concentration: 890 nM
Estimate against measurement, compound 4: 1.0-fold (0.00 log units) above; the measured number falls inside the stated range.
By their numbers in this assay, from the lowest: compound 2; then compounds 1, 4 and 3 (each within the scatter of the next).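

In this assay the first step measured at this position is a 1.3-fold lower number from compound 3 to compound 4 (0.13 log units; within the scatter) and it stays within the scatter, so this exchange on an aromatic carbon gives no readable change. Among the compounds shown here, the result thus shows that 3,5-dimethoxyphenyl and 4-cyanophenyl, which carry different substituents on the same six-membered aromatic ring of carbon only, cannot be told apart at this position in this read-out, which the earlier compounds could not show as they offered no single-place step here. No measurement shown bears on why the number holds across this change.

Still open, as far as these compounds go, is whether any group at this position moves the number beyond the scatter, for example a phenyl ring carrying an amine or a carboxylic acid. Also open, from the compounds shown here alone, is whether this exchange reads the same when the methyl group of compound 2 stands elsewhere on the shared core.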